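A few compounds are considered here, and "the series" means these few. Any claim that something is new, unique, unknown or untested is made for them only; others in the source may bear on it.

All three measured compounds share one core, a substituted pyrimidine carrying a urea-hydrazone arm, and all three give the same reading. Compound 1 `COc1ccc(-c2cc(-c3ccc(F)cc3)nc(NC(=O)N/N=C\c3ccccc3Cl)n2)c(OC)c1` gives 300 mg/kg in a functional assay on the whole organism (strain Albino) with Mus musculus as the target, with a stated time of 4 h; a higher number here means that more compound is needed for the effect, a lower number that less compound is needed. Compound 2 `COc1ccc(-c2cc(-c3ccc(Cl)cc3)nc(NC(=O)N/N=C\c3cccc(Cl)c3)n2)cc1OC` gives 300 mg/kg in this assay. Compound 3 `COc1ccc(-c2cc(-c3ccc(Cl)cc3)nc(NC(=O)N/N=C\c3ccccc3Cl)n2)c(OC)c1` gives 300 mg/kg in this assay. For the measured compounds named here, the one single-point step that is available, no change at the digits printed from compound 1 to compound 3 (within the scatter), changes nothing within the scatter. Compound 3 therefore stands level with compound 1 and with compound 2; compound 2 differs from compound 3 in two places at once, so its value can only be set beside that of compound 3 without a step between them.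

Compound 4 `COc1ccc(-c2cc(-c3ccc(Cl)cc3)nc(NC(=O)N/N=C\c3ccccc3[N+](=O)[O-])n2)c(OC)c1` is the next member: nitro in place of chloro on an aromatic carbon. Going by the values given here, no measured step touches the hydrazone-bearing ring at all, so nothing among the measured compounds bears directly on this change; the only step known, no change at the digits printed from compound 1 to compound 3 (within the scatter), concerns the other aryl ring and was flat. With every measured compound sitting at one level, compound 4 is expected to stay there, no change at the digits printed from compound 3 to compound 4 (within the scatter). The estimate for compound 4 in this assay is 300 mg/kg, with a range from 150 mg/kg to 600 mg/kg.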

Compound 4, dose for half-maximal effect: 300 mg/kg
Beside the measured number, compound 4's estimate shows no gap at the digits printed; measured number inside the range.
By their numbers in this assay, from the lowest: compounds 1, 2, 3 and 4 (each within the scatter of the next).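

In this assay, for the compounds shown here, the exchange of 2-chlorophenyl for 2-nitrophenyl reads as no change at the digits printed from compound 3 to compound 4 (within the scatter), which gives the first reading on the ring that bears the hydrazone arm, whereas the earlier step, no change at the digits printed from compound 1 to compound 3 (within the scatter), concerned the other aryl ring. At this place, on an aromatic carbon ortho to a large group, nitro with its three heavy atoms and two hydrogen-bond acceptors stands in for a single chlorine atom and the reading stays level. Nothing measured on these compounds explains this level reading.

The compounds shown leave open whether an amine or a carboxylic acid at this same place would read any differently. They also leave open whether any group on this ring can move the reading away from the level shared by compounds 1, 2, 3 and 4.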